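From piperidin-4-yl to 4-fluorophenyl on a shared core

The source may hold more compounds than are shown below. What is called first, only, known or untested is meant among the compounds shown, and "the series" means these compounds.

Measured in a functional assay on HCT-116 cells (Homo sapiens) for antiproliferative activity, read by MTT assay, with a stated time of 24 h; a lower number here means a stronger inhibitor, a higher number a weaker inhibitor:
- compound 1 `COc1ccc(-c2noc(-c3ccccc3)n2)cc1OC1CCCC1`: > 1000000 nM (a limit)
- compound 2 `COc1ccc(-c2noc(-c3ccncc3)n2)cc1OC1CCCC1`: > 1000000 nM (a limit)
- compound 3 `COc1ccc(-c2noc(C3CCNCC3)n2)cc1OC1CCCC1`: 1540 nM

Within the data shown here, compound 3 gives 1540 nM, the only true number in this set. The other two values are limits, not numbers: the limit of > 1000000 nM in this assay, at which 2 of the 3 values shown sit.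

Compound 4 `COc1ccc(-c2noc(-c3ccc(F)cc3)n2)cc1OC1CCCC1` has not yet been measured. It carries 4-fluorophenyl in place of piperidin-4-yl on an aromatic carbon.

Among the measured compounds shown here, two measured steps bear on this change. They are an at least 640-fold lower number from compound 1 to compound 3 (2.81 log units; beyond the scatter) and an at least 640-fold lower number from compound 2 to compound 3 (2.81 log units; beyond the scatter), both large and beyond the scatter. Compound 4 runs the same kind of swap the other way, from piperidin-4-yl back to an aromatic ring. Its 4-fluorophenyl differs from the phenyl of compound 1, which reached only a limit of > 1000000 nM.

A large step towards a higher number is therefore expected in this assay, and the assay may well report only a limit. The estimated change is a 650-fold higher number from compound 3 to compound 4 (2.81 log units; beyond the scatter). Compound 4 is estimated at 1000000 nM, with an expected range of 150000 nM to 3000000 nM.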

Compound 4, half-maximal inhibitory concentration: 210000 nM
Beside the measured number, compound 4's estimate is 4.8-fold (0.68 log units) above it; low and high end bracket the measured number.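

In this assay, an aromatic ring at this position can give a true number, and fluoro in place of hydrogen on the phenyl ring comes with an at least 4.7-fold lower number from compound 1 to compound 4 (0.67 log units; beyond the scatter), while 4-fluorophenyl in place of pyridin-4-yl comes with an at least 4.7-fold lower number from compound 2 to compound 4 (0.67 log units; beyond the scatter). Both of these steps are only bounds, as one end of each is a limit and not a number: the limit of > 1000000 nM in this assay, at which 2 of the 4 values shown sit. Piperidin-4-yl still stays well ahead of 4-fluorophenyl, with a 140-fold higher number from compound 3 to compound 4 (2.13 log units; beyond the scatter), so the gap between the non-aromatic ring and an aromatic ring now has a true number at both ends.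

Still open, from the compounds shown here alone, is whether the lower number of compound 3 goes with the ring nitrogen of piperidin-4-yl or with the non-aromatic ring as such; cyclohexyl, the same ring of carbon only, would separate the two. Also open, going by these compounds, is whether chloro in place of fluoro would give a similar step.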